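Swapping an Aromatic Ring for a Cyclopentyl Amine

The source may report more compounds than this note shows. Statements on the series, on what has been measured and on what is new or still open speak of the compounds shown alone.

Compound 1 `O=C1C=C(Nc2ccc(I)cc2)C(=O)c2c1nc1n2[C@H]2OC[C@@H](O)[C@H]2OC1` gives 2230 nM in a functional assay on MCF7 cells (Homo sapiens) for inhibition, read by sulforhodamine B assay (a lower number here means a stronger inhibitor, a higher number a weaker inhibitor), the lower of the two numbers shown. Compound 2 `COc1cccc(NC2=CC(=O)c3c(nc4n3[C@H]3OC[C@@H](O)[C@H]3OC4)C2=O)c1` gives 3830 nM in this assay, and its gap to compound 1 lies within the usual scatter of repeated measurements. For compound 3 `CCOc1ccc(NC2=CC(=O)c3c(nc4n3[C@H]3OC[C@@H](O)[C@H]3OC4)C2=O)cc1` the assay reports only a limit, > 4000 nM, not a number. Within the data shown here, the single step measured between two compounds, an at least 1.0-fold higher number from compound 2 to compound 3 (0.01 log units; that floor lies within the scatter), changes only the substituent on an aromatic ring.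

Compound 4 `O=C1C=C(NC2CCCC2)C(=O)c2c1nc1n2[C@H]2OC[C@@H](O)[C@H]2OC1` differs from compound 1 in another way: cyclopentyl in place of 4-iodophenyl on an amine nitrogen. Among the measured compounds shown here, no measured step here replaces an aromatic ring by a non-aromatic one, so the step from compound 1 to compound 4 has no direct precedent in these data. The expected step, a 2.0-fold higher number from compound 1 to compound 4 (0.30 log units; within the scatter), is a modest weakening with wide uncertainty. Compound 4 is therefore estimated to give about 4500 nM in this assay, expected to fall between 1500 nM and 14000 nM.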

Compound 4, half-maximal inhibitory concentration: > 16000 nM
Compound 4: a limit, no number (the forecaster's own chance of this, stated with the estimate: 45%); at least 3.5-fold (0.55 log units) between middle value and limit.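

The earlier compounds shown here all keep an aromatic ring on the amine nitrogen, so they could show nothing about losing that ring. In this assay, cyclopentyl in place of 4-iodophenyl gives an at least 7.1-fold higher number from compound 1 to compound 4 (0.85 log units; beyond the scatter), the only step shown that lies beyond the scatter, which suggests that this position does not accept every ring of similar size equally. The result for compound 4 is a limit and not a number, so its step gives only a floor and the full size stays unknown: the limit of > 16000 nM in this assay, at which 1 of the 4 values shown sits.

This one change removes the aromatic ring and the iodine together, so the compounds shown cannot say which of the two matters more. A plain phenyl group would separate these two parts of the change, and a cyclohexyl group would test whether another non-aromatic ring behaves like cyclopentyl.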